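Fluoro substitution in a quinone piperazine series

This account rests on a few compounds, and the source may have more. Where it says the series, first, only, none or still open, it means among the compounds named here.

Compound 1 `O=C1C=C(N2CCN(c3cccc(Cl)c3)CC2)C(=O)c2ccccc21` gives 8300 nM in a functional assay on DU-145 cells (Homo sapiens) for inhibition, read by MTT assay, with a stated time of 72 h; a lower number here means a stronger inhibitor, a higher number a weaker inhibitor; compound 2 `O=C1C=C(N2CCN(c3ccc(F)c(Cl)c3)CC2)C(=O)c2ccccc21` gives 32200 nM; compound 3 `O=C1C(N2CCN(c3ccccc3)CC2)=CC(=O)c2c(O)cccc21` gives 15200 nM.

Compound 2 differs from compound 1 by fluoro in place of hydrogen on an aromatic carbon, and this change made a 3.9-fold higher number from compound 1 to compound 2 (0.59 log units; beyond the scatter). Compound 3 and compound 1 have different cores; the difference between the two cores is not broken down here, and the two values of compound 3 and compound 1 lie within the usual scatter of each other.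

Compound 4 `O=C1C(N2CCN(c3ccc(F)cc3)CC2)=CC(=O)c2c(O)cccc21` differs from compound 3 by fluoro in place of hydrogen on an aromatic carbon. This is the same kind of change as that from compound 1 to compound 2, but not the same: in the earlier pair the fluoro sits ortho to a chloro group, while in compound 4 no chloro group is present. Among the measured compounds shown here, on the core of compound 3 the step is therefore expected to run in the same direction but to be smaller, giving an estimated 1.8-fold higher number from compound 3 to compound 4 (0.27 log units; within the scatter), because the only comparable step is a 3.9-fold higher number from compound 1 to compound 2 (0.59 log units; beyond the scatter). Compound 4 is thus estimated at 28000 nM, with a likely range from 12000 nM to 70000 nM.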

Compound 4, half-maximal inhibitory concentration: 22400 nM
Compound 4: the middle estimate sits 1.3-fold (0.10 log units) above what was measured; the range from low to high includes it.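

In this assay the change from phenyl to 4-fluorophenyl on the core of compound 3 gave a 1.5-fold higher number from compound 3 to compound 4 (0.17 log units; within the scatter) and the same kind of change on the core of compound 1 gave a 3.9-fold higher number from compound 1 to compound 2 (0.59 log units; beyond the scatter). Set side by side, the two steps cannot be told apart: the same change on two cores in this assay, a 3.9-fold higher number (0.59 log units; beyond the scatter) from compound 1 to compound 2 and a 1.5-fold higher number (0.17 log units; within the scatter) from compound 3 to compound 4, 2.6-fold (0.42 log units) apart, within the scatter of two such steps. So nothing here shows that the step differs between the two cores, but this does not show that it carries over unchanged either: only two pairs are at hand, and the ring that takes the fluoro group bears a chloro group in compound 1 and none in compound 3.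

The compounds shown leave open how a fluoro group would behave on the core of compound 1 with no chloro group on that ring. They also leave open what a methoxy or trifluoromethyl group in place of the fluoro group would give on either core.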